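This account rests on a few compounds, and the source may have more. Where it says the series, first, only, none or still open, it means among the compounds named here.

Three related compounds have been measured in a functional assay on HT-29 cells (Homo sapiens) for cytotoxicity, read by MTT assay, with a stated time of 72 h; on this read-out higher numbers stand for weaker inhibition of growth and lower numbers for stronger inhibition of growth. Compound 1 `CCCCCSc1nc(NCc2ccc([Se]C)cc2)c2ccccc2n1` gives 14400 nM. Compound 3 `C[Se]c1nc(NCc2ccccc2)c2ccccc2n1`, which carries its selenium-bearing group on the shared core rather than on the benzyl ring, gives 42800 nM. Compound 2 `CSc1nc(NCc2ccc([Se]C)cc2)c2ccccc2n1` reaches only a limit of the assay, > 100000 nM, and so stands among the values that sit at the limit of > 100000 nM in this assay, at which 1 of the 3 values shown sits. Going by the values given here, the single measured step, an at least 6.9-fold higher number from compound 1 to compound 2 (0.84 log units; beyond the scatter), concerns the chain on the sulfur of the core and nothing else.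

Compound 4 `CSc1ccc(CNc2nc(SC)nc3ccccc23)cc1` differs from compound 2 by a group of 2 heavy atoms (1 carbon, 1 sulfur; no ring) in place of a group of 2 heavy atoms (1 carbon, 1 selenium; no ring), on an aromatic carbon. No measured step covers an exchange of selenium for sulfur on the benzyl ring, so the size and direction of the change in this assay cannot be read from the steps shown. The closest guide is compound 2, whose result in this assay is itself only a limit, > 100000 nM. Compound 4 is therefore expected to remain near that limit, with an estimated step of a number no higher from compound 2 to compound 4 (the limit leaves the size open). The estimate for compound 4 is 100000 nM, within a range from 30000 nM to 300000 nM.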

Compound 4, concentration for 50% growth inhibition: 34700 nM
Beside the measured number, compound 4's estimate is 2.9-fold (0.46 log units) above it, within the range that was stated.
By their numbers in this assay, from the lowest: compound 1; then compounds 4 and 3 (each within the scatter of the next). At a limit, above all of these: compound 2.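

In this assay, putting methylsulfanyl in place of the group of one carbon and one selenium, on an aromatic carbon para to a large group, gives an at least 2.8-fold lower number from compound 2 to compound 4 (0.45 log units; beyond the scatter). Going by these compounds alone, the one earlier step changed only the chain on the sulfur of the core, so this is the first sign that exchanging selenium for sulfur at this place on the benzyl ring can move the number beyond the scatter. Only a lower bound on the size of this step can be given, because compound 2 stands at a limit of the assay rather than at a number: the limit of > 100000 nM in this assay, at which 1 of the 4 values shown sits.

Going by these compounds, whether the same exchange would give a similar step with the longer chain of compound 1 on the sulfur of the core remains open. Also open, on these data alone, is what a methoxy group or an amine would do at this same place on the benzyl ring.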